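This account rests on a few compounds, and the source may have more. Where it says the series, first, only, none or still open, it means among the compounds named here.

Inhibition in an assay on isolated protein for inhibition of protein deacetylase HDAC6 (Homo sapiens), read by fluorescence, with a stated time of 90 min, tested at 10 uM (a lower number here means a weaker effect, a higher number a stronger effect of the compound at the concentration tested), measured compounds:
- compound 1, `Cc1cc2cc(NS(=O)(=O)c3cc(C(=O)NO)ccc3Cl)ccc2n(C)c1=O`: 59%
- compound 2, `COc1ccc(C(=O)NO)cc1S(=O)(=O)Nc1ccc2c(c1)cc(C)c(=O)n2C`: 64%
- compound 3, `Cc1cc2cc(NCc3cc(C(=O)NO)ccc3Cl)ccc2n(C)c1=O`: 84%

Compound 3 stands highest of the three numbers in this assay. Its gap to compound 2, the nearest, lies beyond the usual scatter, and its gap to compound 1, the furthest, lies beyond it as well. Compound 1 and compound 2, by contrast, lie within the scatter of each other, so no order is read between those two.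

Compound 4, `COc1ccc(C(=O)NO)cc1CNc1ccc2c(c1)cc(C)c(=O)n2C`, is not yet measured. It differs from compound 3 by methoxy in place of chloro on an aromatic carbon. One measured step carries the same exchange, made on the other pair of the series: a number 5 percentage points higher from compound 1 to compound 2 (within the scatter), a step within the scatter. Nothing else in the set bears on the change. On that basis no step beyond the scatter is expected in this assay for compound 4, in either direction, and the room for a rise is in any case bounded by full inhibition.

Compound 4 is therefore expected to give about 86% in this assay, with a range from 72% to 97%. The expected step is a number 2 percentage points higher from compound 3 to compound 4 (within the scatter), which stays within the scatter.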

Compound 4, a percentage reported as inhibition, at one concentration (the size of the read-out at that concentration, not a potency): 68%
Compound 4: the middle estimate sits 18 percentage points above what was measured; measured number outside the range, below it.
By their numbers in this assay, from the lowest: compounds 1, 2 and 4 (each within the scatter of the next); then compound 3.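

In this assay, methoxy in place of chloro on an aromatic carbon, para to a hydroxycarbamoyl group, does cost inhibition when the linker is the aminomethyl type: a number 16 percentage points lower from compound 3 to compound 4 (beyond the scatter). The exchange therefore cannot be treated as one fixed increment at this position, since its outcome differs between the sulfonamide pair and the aminomethyl pair: the same change on two cores in this assay, a number 5 percentage points higher (within the scatter) from compound 1 to compound 2 and a number 16 percentage points lower (beyond the scatter) from compound 3 to compound 4, 21 percentage points apart, beyond the scatter of two such steps The linker exchange also reads differently with each substituent: with chloro, compound 1 gives 59% and compound 3 gives 84%, a gap beyond the scatter, while with methoxy, compound 2 gives 64% and compound 4 gives 68%, two values within the scatter of each other.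

From the compounds shown here alone, with only chloro and methoxy at this position, it remains open whether the drop on the aminomethyl linker reflects the loss of chloro or the arrival of methoxy, and a plain hydrogen, a fluoro or a methyl group there would help separate the two. Going by these compounds, it also remains open whether the same dependence holds for an amide linker, and these single-concentration read-outs give the size of inhibition rather than a potency.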